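Thiophen-2-yl in place of phenyl on the shared core

A few compounds are considered here, and "the series" means these few. Any claim that something is new, unique, unknown or untested is made for them only; others in the source may bear on it.

Among the measured compounds shown here, in a functional assay on U-937 cells (Homo sapiens) for inhibition, read by MTT assay, with a stated time of 72 h (on this read-out lower numbers stand for stronger inhibition and higher numbers for weaker inhibition), compound 1 (`O=C(NO)c1ccc(CNCc2nc(-c3ccccc3)no2)cc1`) gives 7210 nM and compound 2 (`O=C(NO)c1ccc(CNCc2nc(-c3ccc(C(F)(F)F)cc3)no2)cc1`) gives 8050 nM as its sole neighbour, and the two lie within the scatter of each other. Compound 3 (`O=C(NO)c1ccc(CNCc2nc(-c3cccs3)no2)cc1`) carries thiophen-2-yl in place of phenyl on an aromatic carbon. For the measured compounds named here, only one measured step bears on this change, and it keeps the phenyl: trifluoromethyl in place of hydrogen on an aromatic carbon gave a 1.1-fold higher number from compound 1 to compound 2 (0.05 log units; within the scatter) as its whole effect. The expected move is therefore a 1.0-fold lower number from compound 1 to compound 3 (0.01 log units; within the scatter) and nothing beyond the scatter in this assay is expected. For compound 3 the estimated value is 7000 nM (expected range 3200 nM to 14000 nM).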

Compound 3, half-maximal inhibitory concentration: 10700 nM
The estimate for compound 3 lay 1.5-fold (0.18 log units) below the measured number; the range from low to high includes it.
By their numbers in this assay, from the lowest: compounds 1, 2 and 3 (each within the scatter of the next).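

In this assay, replacing the whole phenyl ring with thiophen-2-yl gives a 1.5-fold higher number from compound 1 to compound 3 (0.17 log units; within the scatter) and so, unlike the earlier step, tests the ring itself rather than a substituent on it. A five-membered aromatic ring with a sulfur atom therefore leaves the number within the scatter of the phenyl compound at this place on the shared core. No available evidence bears on this result. The compounds shown leave open whether a pyridin-3-yl ring, a cyclohexyl group or an amine at this place would give a step beyond the scatter.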